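The source may report more compounds than this note shows. Statements on the series, on what has been measured and on what is new or still open speak of the compounds shown alone.

Working notes on the series. Compound 1 `O=S(=O)(Nc1cccc(CO)c1)c1ccc(-c2ccc3[nH]ccc3c2)cc1` carries 1H-indol-5-yl on the shared core. In a functional assay on J774 cells (Mus musculus) for cytotoxicity, read by resazurin assay, with a stated time of 72 h (on this read-out lower numbers stand for stronger inhibition and higher numbers for weaker inhibition), compound 1 reaches only a limit of the assay, > 5000 nM, and that is a limit rather than a number (the limit of > 5000 nM in this assay, at which 1 of the 3 values shown sits). Compound 2 `O=S(=O)(Nc1cccc(CO)c1)c1ccc(-c2ccc(Cl)cc2)cc1` gives 2500 nM in this assay. Compound 3 `O=S(=O)(Nc1cccc(CO)c1)c1ccc(-c2ccc(F)cc2)cc1` gives 3500 nM in this assay. Of the two numbers, compound 3 holds the higher one, and its nearest neighbour is compound 2; the step of a 1.4-fold higher number from compound 2 to compound 3 (0.15 log units; within the scatter) lies within the scatter, so the two read as equivalent. The steps of an at least 2.0-fold lower number from compound 1 to compound 2 (0.30 log units; that floor lies within the scatter) and an at least 1.4-fold lower number from compound 1 to compound 3 (0.15 log units; that floor lies within the scatter) start from a limit and give only a floor.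

Compound 4 `CC(=O)Nc1ccc(-c2ccc(S(=O)(=O)Nc3cccc(CO)c3)cc2)cc1` differs from compound 3 by acetamido in place of fluoro on an aromatic carbon. Within the data shown here, none of the measured steps changes a halogen into an acetamido; the only step that touches this position is a 1.4-fold higher number from compound 2 to compound 3 (0.15 log units; within the scatter), which stayed within the scatter, while the remaining two steps exchange the whole aryl group. For compound 4 a step of a 1.1-fold higher number from compound 3 to compound 4 (0.06 log units; within the scatter) is therefore expected, none beyond the scatter. The estimate for compound 4 in this assay is 4000 nM, with a range from 1500 nM to 12000 nM.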

Compound 4, half-maximal inhibitory concentration: > 5000 nM
Compound 4: no number, only a limit; the forecaster's own chance of this, stated with the estimate: 35%; middle value at least 1.2-fold (0.09 log units) away from the limit.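

In this assay compound 4 gives > 5000 nM, which is a limit of the assay and not a number, so acetamido joins the 1H-indol-5-yl group of compound 1 at that limit: the limit of > 5000 nM in this assay, at which 2 of the 4 values shown sit.

The steps of an at least 1.4-fold higher number from compound 3 to compound 4 (0.15 log units; that floor lies within the scatter) and an at least 2.0-fold higher number from compound 2 to compound 4 (0.30 log units; that floor lies within the scatter) give only floors, so this change is not shown to move the read-out beyond the scatter. Among these compounds, what the earlier compounds did not show is that a group other than a halogen, with 4 heavy atoms, 1 hydrogen-bond donor and 1 hydrogen-bond acceptor in place of the single fluorine, brings no lower number at this place on the ring, while the true size of the step stays unknown.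

The compounds shown leave open how far the true values of compound 1 and compound 4 lie past the limit, and whether the amide hydrogen or the carbonyl has any bearing on the result. As far as these compounds go, it also stays open whether an amine, a methoxy group or a carboxylic acid on this aromatic carbon would give a readable number in this assay.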